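The compounds below may be only part of what the source reports. "The series", "measured", "known", "first", "only" and "open" are said of these compounds alone.

Working notes on the series. The shared core is that of compound 1 `C=CC1=C(C(=O)NCc2ccc(Cl)cc2)C(c2ccc(F)cc2)OC1`, which carries 4-chlorobenzyl on the amide-type nitrogen. In a functional assay on SW480 cells (Homo sapiens) for cytotoxicity, read by MTT assay, with a stated time of 24 h (a higher number here means a weaker inhibitor, a lower number a stronger inhibitor), compound 1 gives > 100000 nM, a limit of the assay and not a number. Compound 2 `C=CC1=C(C(=O)NC(C)(C)C)C(c2ccc(F)cc2)OC1` has tert-butyl in place of 4-chlorobenzyl on that nitrogen. In this assay compound 2 gives > 100000 nM, again a limit of the assay and not a number. The step that the two limits leave unreadable from compound 1 to compound 2 is therefore not readable in either direction; both compounds sit at the limit of > 100000 nM in this assay, at which 2 of the 2 values shown sit. Compound 2 thus stands at the limit, and nothing places it anywhere inside the measured range.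

Compound 3 `C=CC1=C(C(=O)NCc2ccccc2)C(c2ccc(F)cc2)OC1` is still to be measured. The change is benzyl in place of tert-butyl on an amide-type nitrogen. For the measured compounds named here, the only measured step that bears on it is the one from compound 1 to compound 2, which is unreadable in size, so benzyl, which lies between 4-chlorobenzyl and tert-butyl on this nitrogen, gives no ground to expect any step beyond the scatter. In this assay compound 3 is expected at 100000 nM, with a range from 30000 nM to 300000 nM, most likely reported again as a limit. The step of a number no higher from compound 2 to compound 3 (the limit leaves the size open) is expected to be none beyond the scatter.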

Compound 3, half-maximal inhibitory concentration: > 100000 nM
Compound 3: only a limit was reported; the forecaster's own chance of this, stated with the estimate: 85%; the middle value sits exactly at the limit.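

In this assay compound 3 gives > 100000 nM, a limit of the assay and not a number. No step from compound 1 or compound 2 to compound 3 can be read: the limit of > 100000 nM in this assay, at which 3 of the 3 values shown sit.

The compounds shown leave open whether any group on the amide-type nitrogen of the shared core gives a measurable value in this assay.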